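Moving the chlorine on a five-membered core: compound 2 to compound 4

The compounds below may be only part of what the source reports. "The series", "measured", "known", "first", "only" and "open" are said of these compounds alone.

Of the compounds shown here, three sharing a five-membered aromatic ring have been tested in a functional assay on HL-60 cells (Homo sapiens) for inhibition, read by MTT assay, with a stated time of 72 h; on this read-out lower numbers stand for stronger inhibition and higher numbers for weaker inhibition. Compound 1 `CCc1nc(-c2ccc(OC)c(OC)c2)c(C(=O)N2CCN(c3cccc(Cl)c3)CC2)o1` gives "not active" (no number reported) in this assay. Compound 2 `Cc1ccc(C)c(N2CCN(C(=O)c3oc(C)nc3-c3ccc(Cl)cc3)CC2)c1` likewise gives "not active" (no number reported) in this assay, so no single number stands for it. Of the other two entries, one is again without a number and one, that of compound 3, is a limit. Compound 3 `Cc1nc(-c2ccccc2)c(C(=O)N2CCN(c3ccc(C(F)(F)F)cc3)CC2)o1` reaches only a limit of the assay, > 1000 nM in this assay, which is the limit of > 1000 nM in this assay, at which 1 of the 3 values shown sits.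

Compound 4 `Cc1ccc(C)c(N2CCN(C(=O)c3oc(C)nc3-c3cccc(Cl)c3)CC2)c1` is not yet measured. It carries the same atoms as compound 2 joined differently: 3-chlorophenyl in place of 4-chlorophenyl on an aromatic carbon. For the measured compounds named here, with no measured step to lean on and every known value sitting at or beyond the edge of detection, no shift beyond the usual scatter of this assay is expected from this change, in either direction.

Compound 4 is therefore expected to give roughly 5000 nM, with a range from 1000 nM to 30000 nM, and most likely only a limit will be reported.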

Compound 4, half-maximal inhibitory concentration: 345 nM
For compound 4 the middle estimate is 14-fold (1.16 log units) above the measured one; measured number below the stated range.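

Compound 2 has no number, so no step to compound 4, at 345 nM, can be read, and nothing given here explains that value. Still open, on these data alone, is how 3-chlorophenyl in place of 4-chlorophenyl would read on a pair where both compounds carry a number.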